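The source may hold more compounds than are shown below. What is called first, only, known or untested is meant among the compounds shown, and "the series" means these compounds.

Among the measured compounds shown here, compound 3 `CC1=NN(c2ccc(C)cc2)C(=O)C12C=CC(=O)C=C2c1ccc(C)cc1` sits second highest of the three numbers so far in a functional assay on MDA-MB-231 cells (Homo sapiens) for antiproliferative activity, read by CCK-8 assay, with a stated time of 72 h; on this read-out higher numbers stand for weaker inhibition and lower numbers for stronger inhibition: compound 3 gives 5110 nM, close to compound 1 `CC1=NN(c2ccc(Br)cc2)C(=O)C12C=CC(=O)C=C2c1cccc(C)c1`, which gives 2890 nM, and far from compound 2 `CC1=NN(c2ccccc2)C(=O)C12C=CC(=O)C=C2c1cccc(C)c1`, which gives 85800 nM. For the measured compounds named here, the only single change measured, a 30-fold higher number from compound 1 to compound 2 (1.47 log units; beyond the scatter), removed a halogen from the aromatic ring on the nitrogen. Compound 4 `CC1=NN(c2ccc(C)cc2)C(=O)C12C=CC(=O)C=C2c1ccccc1` instead differs from compound 3 at the other aromatic ring: hydrogen in place of methyl on an aromatic carbon. Going by the values given here, no step on that ring has been measured, so the bromo step is only a loose guide, pointing towards weaker inhibition when a substituent is lost. Compound 4 is therefore expected to give a higher number, estimated at 12000 nM, within 4000 nM to 40000 nM, a step of a 2.3-fold higher number from compound 3 to compound 4 (0.37 log units; beyond the scatter).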

Compound 4, half-maximal inhibitory concentration: 46600 nM
Compound 4: the middle estimate sits 3.9-fold (0.59 log units) below what was measured; measured number above the stated range.
By their numbers in this assay, from the lowest: compounds 1 and 3 (each within the scatter of the next); then compounds 4 and 2 (each within the scatter of the next).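

In this assay the step on this ring, a 9.1-fold higher number from compound 3 to compound 4 (0.96 log units; beyond the scatter), shows that the methyl para to a large group matters: going from 4-methylphenyl to phenyl weakens inhibition beyond the scatter. The step of a 30-fold higher number from compound 1 to compound 2 (1.47 log units; beyond the scatter) runs the same way, so in both pairs shown, losing a substituent from an aromatic ring weakens inhibition. No measurement here explains the effect of the methyl. As far as these compounds go, whether a methoxy, a chlorine or a longer chain such as ethyl at this place would match the methyl stays open. So does whether an amine there would keep any of this inhibition.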